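Compound 4 and a Halophenyl Swap at the Assay Limit

The source may report more compounds than this note shows. Statements on the series, on what has been measured and on what is new or still open speak of the compounds shown alone.

Compound 3 `FC(F)(F)c1ccc(CSc2nc(Nc3ccccc3Cl)c3ccccc3n2)cc1` was examined in a functional assay on MDA-MB-231 cells (Homo sapiens) for cytotoxicity, read by MTT assay, with a stated time of 72 h; a higher number here means a weaker inhibitor, a lower number a stronger inhibitor. In this assay compound 3 returns only a limit of the assay, > 50000 nM. Its two chain-bearing relatives fare no differently. In this assay compound 1 `CCCCCCCCCCCCNc1nc(SCc2ccc(C(F)(F)F)cc2)nc2ccccc12` likewise gives only a limit, > 50000 nM. In this assay compound 2 `CCCCCCCCCCCCCCNc1nc(SCc2ccc(C(F)(F)F)cc2)nc2ccccc12` also gives only a limit, > 50000 nM. The step that the two limits leave unreadable from compound 1 to compound 2 therefore cannot be read, and the whole measured set is summed up by the limit of > 50000 nM in this assay, at which 3 of the 3 values shown sit.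

Compound 4 `FC(F)(F)c1ccc(CSc2nc(Nc3cccc(Br)c3)c3ccccc3n2)cc1` differs from compound 3 by 3-bromophenyl in place of 2-chlorophenyl on a nitrogen on an aromatic ring. Among the measured compounds shown here, no measured step bears on this change: the only step recorded, between compounds 1 and 2, is unreadable, and compound 3 is the sole measured compound carrying a halophenyl group on that nitrogen. Without any readable movement in the series, the step of a number no higher from compound 3 to compound 4 (the limit leaves the size open) is expected to stay within the scatter, most likely leaving compound 4 at the limit as well. Compound 4 is estimated at 50000 nM, within a range from 15000 nM to 200000 nM.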

Compound 4, half-maximal inhibitory concentration: 22100 nM
Compound 4: middle estimate off by 2.3-fold (0.35 log units), on the high side; measured number inside the range.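

In this assay, putting 3-bromophenyl in place of 2-chlorophenyl on a nitrogen on an aromatic ring gives an at least 2.2-fold lower number from compound 3 to compound 4 (0.35 log units; beyond the scatter). Among the compounds shown here, this is the first readable movement in the set, as the step between the two chain-bearing compounds cannot be read, and it shows that the group on this nitrogen can bring a compound off the limit. Compound 4 is the only compound shown with a number rather than a limit: the limit of > 50000 nM in this assay, at which 3 of the 4 values shown sit.

The swap changes both the halogen and its place on the phenyl ring, so the compounds shown leave open which of the two matters, a question that 3-chlorophenyl or 2-bromophenyl on the same nitrogen would address. Also open, going by these compounds, is how far the number would move with plain phenyl or 3-methoxyphenyl there.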